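Methyl on the indole nitrogen in two stilbene-like cores

The source may hold more compounds than are shown below. What is called first, only, known or untested is meant among the compounds shown, and "the series" means these compounds.

Of the compounds shown here, three have been measured in a functional assay on HT-29 cells (Homo sapiens) for inhibition; a higher number here means a weaker inhibitor, a lower number a stronger inhibitor. Compound 1, `COc1cc(/C=C\c2c[nH]c3ccccc23)cc(OC)c1OC`, gives 3230 nM. Compound 2, `COc1cc(/C=C\c2cn(C)c3ccccc23)cc(OC)c1OC`, gives 3090 nM. The two differ only in one spot: methyl in place of hydrogen on an aromatic nitrogen. The step of a 1.0-fold lower number from compound 1 to compound 2 (0.02 log units; within the scatter) shows that this swap leaves the read-out essentially unchanged.

Compound 3, `COc1cc(/C=C/c2ccc3[nH]ccc3c2)cc(OC)c1OC`, is built from the same atoms as compound 1 but joined differently, and the difference between the two cores is not broken down here. In this assay compound 3 gives 280 nM, the lowest number of the three and beyond the scatter relative to both compound 1 and compound 2, so it is the strongest inhibitor measured so far.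

Compound 4, `COc1cc(/C=C/c2ccc3c(ccn3C)c2)cc(OC)c1OC`, has not yet been measured. It relates to compound 3 as compound 2 relates to compound 1: methyl in place of hydrogen on an aromatic nitrogen. The surroundings are not identical, since in the pair of compound 1 and compound 2 the nitrogen sits two ring bonds from the ring atom that bears a large group, whereas in compound 3 and compound 4 it does not; the change is therefore the same kind of change rather than the same change.

A step of about a 1.1-fold higher number from compound 3 to compound 4 (0.03 log units; within the scatter) is expected, because a 1.0-fold lower number from compound 1 to compound 2 (0.02 log units; within the scatter) showed that adding the methyl on the aromatic nitrogen barely moved the number. Compound 4 is therefore estimated at 300 nM, with a likely range from 150 nM to 650 nM.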

Compound 4, half-maximal inhibitory concentration: 280 nM
Compound 4: the middle estimate sits 1.1-fold (0.03 log units) above what was measured, within the range that was stated.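

In this assay, the second core gives the same answer as the first when methyl replaces hydrogen on the aromatic nitrogen, with no change at the digits printed from compound 3 to compound 4 (within the scatter). Set side by side, the two steps cannot be told apart, so the change carries over from one core to the other in this series: the same change on two cores in this assay, a 1.0-fold lower number (0.02 log units; within the scatter) from compound 1 to compound 2 and no change at the digits printed (within the scatter) from compound 3 to compound 4, 1.0-fold (0.02 log units) apart, within the scatter of two such steps. This shows only that, in these two pairs and in this one read-out, the hydrogen on that nitrogen can give way to methyl without a visible shift in the number; it does not explain why the number stays put, and two pairs are too few to predict what the same swap would do on any other core.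

From the compounds shown here alone, what stays open is whether this tolerance extends beyond methyl, for example to an ethyl group, a longer chain, or a chain ending in an amine or a carboxylic acid on the same nitrogen. The compounds shown also leave open whether the nitrogen needs to carry any group at all in other kinds of measurement, since everything here comes from a single cell-based read-out.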